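Fluoro for hydrogen: from compound 2 to compound 3

The source may report more compounds than this note shows. Statements on the series, on what has been measured and on what is new or still open speak of the compounds shown alone.

compound 1 `Cc1ccnc(Oc2ccc3nc(COc4cccc(C(=O)O)c4)n(C)c3c2)c1` — 33 ug/mL
compound 2 `Cc1cccnc1Oc1ccc2nc(COc3cccc(C(=O)O)c3)n(C)c2c1` — 37 ug/mL

In a physicochemical assay for solubility, read by HPLC, measured as thermodynamic solubility, with a stated time of 4 h, at pH 6.8 (a lower number here means a less soluble compound, a higher number a more soluble compound), compound 2 gives 37 ug/mL and compound 1 gives 33 ug/mL; the two lie within the scatter of each other, so neither stands apart. Among the measured compounds shown here, the only measured step, a 1.1-fold higher number from compound 1 to compound 2 (0.05 log units; within the scatter), exchanges one methylpyridinyl for another and does not test fluoro for hydrogen. Compound 3 `Cc1cc(F)cnc1Oc1ccc2nc(COc3cccc(C(=O)O)c3)n(C)c2c1` differs from compound 2 by fluoro in place of hydrogen on an aromatic carbon. For the measured compounds named here, no measured step bears on this change, so no direction beyond the scatter is claimed. Compound 3 is expected close to compound 2, a 1.5-fold lower number from compound 2 to compound 3 (0.17 log units; within the scatter), estimated at 25 ug/mL with a range of 9 ug/mL to 70 ug/mL.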

Compound 3, solubility: 14 ug/mL
Estimate against measurement, compound 3: 1.8-fold (0.25 log units) above; the measured number falls inside the stated range.
By their numbers in this assay, from the lowest: compound 3; then compounds 1 and 2 (each within the scatter of the next).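

a 2.6-fold lower number from compound 2 to compound 3 (0.42 log units; beyond the scatter) in this assay is the first step in the series beyond the scatter, and it comes from fluoro in place of hydrogen on an aromatic carbon two atoms from the ring nitrogen. The wider exchange of 4-methylpyridin-2-yl for 5-fluoro-3-methylpyridin-2-yl reads similarly, a 2.4-fold lower number from compound 1 to compound 3 (0.37 log units; beyond the scatter), whereas the two methylpyridinyl compounds lay within the scatter of each other. No measurement on hand accounts for this lower number.

Going by these compounds, whether the step is particular to fluoro remains open, since a chloro or methoxy group at this carbon would test that directly. Also open, on these data alone, is whether the same fluoro change holds on the 4-methylpyridin-2-yl of compound 1.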